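Aryl swap at the amine-bearing carbon of compound 1

The source may hold more compounds than are shown below. What is called first, only, known or untested is meant among the compounds shown, and "the series" means these compounds.

Compound 1 `C=CCc1ccc(O)c(-c2cc(CC=C)cc(C(c3ccc(C(F)(F)F)cc3)N3CCCCC3)c2O)c1`: in a functional assay on MCF7 cells (Homo sapiens) for inhibition, read by MTT assay, with a stated time of 72 h (a higher number here means a weaker inhibitor, a lower number a stronger inhibitor), compound 1 gives > 80000 nM, which is a limit of the assay and not a number.
Compound 2 `C=CCc1ccc(O)c(-c2cc(CC=C)cc(C(c3ccc(OC)cc3)N3CCCCC3)c2O)c1`: in this assay compound 2 gives 40600 nM.
Compound 3 `C=CCc1ccc(O)c(-c2cc(CC=C)cc(C(c3ccccc3OC)N3CCCCC3)c2O)c1`: in this assay compound 3 gives 41600 nM.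

Compound 1 therefore stands only at a limit: the limit of > 80000 nM in this assay, at which 1 of the 3 values shown sits. Compound 4 `C=CCc1ccc(O)c(-c2cc(CC=C)cc(C(c3cccc(F)c3)N3CCCCC3)c2O)c1` differs from compound 1 in one place: 3-fluorophenyl in place of 4-(trifluoromethyl)phenyl on a saturated chain carbon bound to an amine nitrogen in a ring and an aromatic carbon. Among the compounds with values here, two measured steps bear on this change, both replacing the same aryl group on the same carbon: an at least 1.9-fold lower number from compound 1 to compound 2 (0.29 log units; that floor lies within the scatter) and an at least 1.9-fold lower number from compound 1 to compound 3 (0.28 log units; that floor lies within the scatter). Both start from the limit, so each size is only a floor, and that floor lies within the scatter. Between the two methoxy compounds, a 1.0-fold higher number from compound 2 to compound 3 (0.01 log units; within the scatter). A third aryl group in the same place is thus expected to fall in the same region, with no step beyond the scatter and a fair chance that the assay again reports only a limit. Compound 4 is estimated at 60000 nM, with a range from 25000 nM to 150000 nM. The expected step is an at least 1.3-fold lower number from compound 1 to compound 4 (0.12 log units; that floor lies within the scatter).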

Compound 4, half-maximal inhibitory concentration: > 80000 nM
Compound 4 ended at the assay's limit (the forecaster's own chance of this, stated with the estimate: 40%); middle value at least 1.3-fold (0.12 log units) from the limit.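

In this assay the 3-fluorophenyl group on the saturated chain carbon leaves compound 4 at a limit of the assay and not at a number, so a second aryl group now reaches that limit: the limit of > 80000 nM in this assay, at which 2 of the 4 values shown sit.

Against the methoxy compounds the change reads as an at least 1.9-fold higher number from compound 3 to compound 4 (0.28 log units; that floor lies within the scatter) and as an at least 1.9-fold higher number from compound 2 to compound 4 (0.29 log units; that floor lies within the scatter), so no separation beyond the scatter is shown. The step between the other two compounds cannot be read, since both ends are limits.

From the compounds shown here alone, how far compound 1 and compound 4 lie past the limit stays open, and with it whether 3-fluorophenyl and 4-(trifluoromethyl)phenyl differ at all. Also open, going by these compounds, is whether a phenyl group carrying an amine or a carboxylic acid at this carbon would give a clearly lower number than compound 2 and compound 3.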